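Sulfonyl series: from compound 3 to compound 4

The source may hold more compounds than are shown below. What is called first, only, known or untested is meant among the compounds shown, and "the series" means these compounds.

- compound 1 `COc1ccc(S(=O)(=O)c2cc3cnc(Nc4ccc5[nH]ccc5c4)nc3n(C)c2=O)cc1`: 300 nM
- compound 2 `Cn1c(=O)c(C(=O)Nc2ccc(F)cc2)cc2cnc(Nc3ccc4[nH]ccc4c3)nc21`: 5000 nM
- compound 3 `Cn1c(=O)c(S(=O)(=O)Nc2ccc(F)cc2)cc2cnc(Nc3ccc4[nH]ccc4c3)nc21`: 5000 nM

Compound 3 shares the highest of the three numbers in a functional assay on K562 cells (Homo sapiens) for inhibition, read by trypan blue exclusion, with a stated time of 72 h (a higher number here means a weaker inhibitor, a lower number a stronger inhibitor), with compound 2. Sulfamoyl in place of carbamoyl gave no change at the digits printed from compound 2 to compound 3 (within the scatter). Compound 4 `Cn1c(=O)c(S(=O)(=O)c2ccc(N)cc2F)cc2cnc(Nc3ccc4[nH]ccc4c3)nc21` is reached by 4-amino-2-fluorophenyl in place of (4-fluorophenyl)amino on a sulfonyl sulfur. Compound 4 thus has an aryl ring on the sulfonyl sulfur, as compound 1 does. The most relevant measured step is a 17-fold higher number from compound 1 to compound 3 (1.22 log units; beyond the scatter). Read in reverse, it points to a lower number, although no measured compound carries the new ring. The expected step in this assay is large, a 10-fold lower number from compound 3 to compound 4 (1.00 log units; beyond the scatter). For compound 4 the estimated value is 500 nM, with a range of 120 nM to 2500 nM.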

Compound 4, half-maximal inhibitory concentration: 1500 nM
Beside the measured number, compound 4's estimate is 3.0-fold (0.48 log units) below it, and the stated range covers the measured number.
By their numbers in this assay, from the lowest: compound 1; then compound 4; then compounds 2 and 3 (each within the scatter of the next).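

In this assay, an aryl ring placed directly on the sulfonyl sulfur gives a lower number than either linked anilide-type compound (a 3.3-fold lower number from compound 3 to compound 4 (0.52 log units; beyond the scatter); a 3.3-fold lower number from compound 2 to compound 4 (0.52 log units; beyond the scatter)). The aryl ring alone does not settle the outcome: 4-amino-2-fluorophenyl in place of 4-methoxyphenyl gives a higher number (a 5.0-fold higher number from compound 1 to compound 4 (0.70 log units; beyond the scatter)), so the ring's substituents also matter. No evidence on the cause of these steps is available.

The compounds shown do not separate the contributions of the amino group and the fluorine on this ring. Going by these compounds, how an unsubstituted phenyl or a 4-(dimethylamino)phenyl on the sulfonyl sulfur would read remains open.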